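The source may report more compounds than this note shows. Statements on the series, on what has been measured and on what is new or still open speak of the compounds shown alone.

In a functional assay on the whole organism (strain STD-ddY) with Mus musculus as the target, with stated times of 1 h and 24 h (on this read-out higher numbers stand for an effect only at larger amounts of compound and lower numbers for an effect already at smaller amounts), three compounds built on one shared core have been examined. Compound 1 `O=C(CCCN1CCC(n2cnc3ccccc32)CC1)c1ccc(F)cc1` carries hydrogen on an aromatic carbon of that core, and in this assay compound 1 reaches only a limit, > 3 mg/kg. Compound 2 `Cc1nc2ccccc2n1C1CCN(CCCC(=O)c2ccc(F)cc2)CC1` carries methyl in place of that hydrogen, and in this assay compound 2 gives 0.81 mg/kg. This single exchange produces an at least 3.7-fold lower number from compound 1 to compound 2 (0.56 log units; beyond the scatter). Compound 3 `O=C(CCCSc1nc2ccccc2n1C1CCN(CCCC(=O)c2ccc(F)cc2)CC1)c1ccc(F)cc1` is a larger relative, and in this assay compound 3 again reaches only a limit, > 3 mg/kg, which is the limit of > 3 mg/kg in this assay, at which 2 of the 3 values shown sit. Among the measured compounds shown here, compound 3 therefore stands among the values that are limits rather than numbers, with compound 2 the only one carrying a number.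

Compound 4 `O=C(CCCN1CCC(n2c(SCC(=O)c3ccc(Cl)cc3)nc3ccccc32)CC1)c1ccc(F)cc1` differs from compound 3 in one place: (4-chlorophenyl)carbonyl in place of 2-((4-fluorophenyl)carbonyl)ethyl on a saturated chain carbon bound to a sulfur. For the measured compounds named here, none of the measured steps covers an exchange on a saturated chain carbon bound to a sulfur; the only measured step concerns methyl against hydrogen on an aromatic carbon, a different place. Compound 4 keeps the sulfur-linked arm that compound 3 has, and compound 3 sits at a limit. The expected step for compound 4 is about a number no higher from compound 3 to compound 4 (the limit leaves the size open) in this assay, that is, none beyond the scatter, with a fair chance of again only a limit. Compound 4 is estimated at 3 mg/kg in this assay, within 1 mg/kg to 10 mg/kg.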

Compound 4, dose for half-maximal effect: 1.6 mg/kg
Compound 4: the middle estimate sits 1.9-fold (0.27 log units) above what was measured, and the stated range covers the measured number.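

With the exchange on the saturated chain carbon bound to a sulfur, the sulfur-linked arm now comes with a real number in this assay, so this arm does not by itself hold a compound at a limit, although compound 3 carries such an arm and does stay at one. The exchange gives an at least 1.8-fold lower number from compound 3 to compound 4 (0.27 log units; that floor lies within the scatter), and the arm in place of hydrogen on the aromatic carbon gives an at least 1.8-fold lower number from compound 1 to compound 4 (0.27 log units; that floor lies within the scatter); both are only floors, their true sizes stay open, and limits still mark much of this small set: the limit of > 3 mg/kg in this assay, at which 2 of the 4 values shown sit.

Set against methyl on that aromatic carbon, the arm gives a 2.0-fold higher number from compound 2 to compound 4 (0.30 log units; within the scatter), so in this read-out the small methyl and the much larger (((4-chlorophenyl)carbonyl)methyl)sulfanyl group cannot be told apart.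

The exchange alters the chain and swaps fluorine for chlorine together, and the compounds shown do not separate these two changes. They also leave open what an amine, a carboxylic acid or a longer chain would do on the saturated chain carbon bound to a sulfur.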